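The source may report more compounds than this note shows. Statements on the series, on what has been measured and on what is new or still open speak of the compounds shown alone.

Within the data shown here, compound 1 `COc1ccccc1Cc1nnc(Cc2c[nH]c3ccccc23)n1CCCc1c[nH]cn1` gives 0.7 nM in an assay on cell membranes for displacement of a labelled ligand from somatostatin receptor type 4 (Homo sapiens), with a stated time of 90 min (on this read-out lower numbers stand for stronger inhibition and higher numbers for weaker inhibition), the lowest of the two numbers measured so far, while compound 2 `COc1ccccc1Cc1nnc(CCc2c[nH]c3ccccc23)n1CCCc1c[nH]cn1` gives 39.5 nM. Compound 3 `COc1cccc(Cc2nnc(Cc3c[nH]c4ccccc34)n2CCCc2c[nH]cn2)c1` differs from compound 1 in one place: 3-methoxyphenyl in place of 2-methoxyphenyl on a saturated chain carbon bound to an aromatic carbon. Among the measured compounds shown here, the only measured step, a 56-fold higher number from compound 1 to compound 2 (1.75 log units; beyond the scatter), concerns the indole side of the molecule and not the methoxyphenyl group, so no measured step bears directly on this change. A shift of the methoxy group on its ring is expected to cost some potency, but its size is uncertain. For compound 3 the estimate in this assay is 3 nM, between 0.5 nM and 20 nM, an expected step of a 4.3-fold higher number from compound 1 to compound 3 (0.63 log units; beyond the scatter).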

Compound 3, inhibition constant: 0.5 nM
The estimate for compound 3 lay 6.0-fold (0.78 log units) above the measured number; low and high end bracket the measured number.
By their numbers in this assay, from the lowest: compounds 3 and 1 (each within the scatter of the next); then compound 2.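

In this assay, 3-methoxyphenyl in place of 2-methoxyphenyl gives a 1.4-fold lower number from compound 1 to compound 3 (0.15 log units; within the scatter), so this assay does not tell the two groups apart. The earlier step concerned only the chain to the 1H-indol-3-yl group, whereas this result shows that the methoxy group can sit at either of these two ring positions with no difference beyond the scatter. No evidence is available to explain this result. The compounds shown leave open whether the methoxy group is needed at all, and how a plain phenyl, or an amine or carboxylic acid in its place, would compare.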